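This account rests on a few compounds, and the source may have more. Where it says the series, first, only, none or still open, it means among the compounds named here.

In an ADME assay on BJ cells (Homo sapiens) for cytotoxicity, read by MTT assay, with a stated time of 72 h (a lower number here means that less compound is tolerated, a higher number that more compound is tolerated), compound 3 (`CCCCCCCCCCCCCCCCCCOP(=O)(O)OC[C@H]1O[C@@H](n2ccc3c(-c4ccco4)ncnc32)[C@H](O)[C@@H]1O`), which carries an octadecyl phosphate, gives > 50000 nM, and this is a limit of the assay and not a number. That places compound 3 at the limit of > 50000 nM in this assay, at which 1 of the 3 values shown sits, so no exact starting point exists for the step ahead. Compound 4 (`CCCCCCCCCCCCCCCCCCOP(=O)(O)OC[C@H]1O[C@@H](n2ccc3c(-c4ccsc4)ncnc32)[C@H](O)[C@@H]1O`) has thiophen-3-yl in place of furan-2-yl on an aromatic carbon. Going by the values given here, no measured step makes this exchange directly. The nearest evidence comes from two compounds without the octadecyl phosphate and with a fluorine on the core. Compound 1 (`OC[C@H]1O[C@@H](n2cc(F)c3c(-c4ccsc4)ncnc32)[C@H](O)[C@@H]1O`), which carries thiophen-3-yl, gives 620 nM, and compound 2 (`OC[C@H]1O[C@@H](n2cc(F)c3c(-c4ccc[nH]4)ncnc32)[C@H](O)[C@@H]1O`), with 1H-pyrrol-2-yl on that carbon, gives 2990 nM. Among the compounds with values here, the single step between them is a 4.8-fold higher number from compound 1 to compound 2 (0.68 log units; beyond the scatter), which shows that the group on this carbon can move this assay beyond the scatter, with the thiophen-3-yl compound at the lower number. A modest move to a lower number is therefore expected, though compound 4 may well remain at the limit. The expected step is an at least 1.4-fold lower number from compound 3 to compound 4 (0.15 log units; that floor lies within the scatter). Compound 4 is estimated at 35000 nM, with an expected range from 8000 nM to 60000 nM.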

Compound 4, half-maximal cytotoxic concentration: > 50000 nM
Compound 4 gave a limit, no number (the forecaster's own chance of this, stated with the estimate: 45%); middle value at least 1.4-fold (0.15 log units) from the limit.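

In this assay compound 4 gives > 50000 nM as a limit of the assay and not a number. Going by these compounds alone, compound 3 also stands at a limit, so no step from furan-2-yl to thiophen-3-yl can be read between compound 3 and compound 4: the limit of > 50000 nM in this assay, at which 2 of the 4 values shown sit.

The compounds shown leave open whether this group changes the tolerated concentration at all when the octadecyl phosphate is present.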